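The source may report more compounds than this note shows. Statements on the series, on what has been measured and on what is new or still open speak of the compounds shown alone.

Measured so far in a functional assay on RS4-11 cells (Homo sapiens) for inhibition, read by CCK-8 assay, with a stated time of 48 h; a lower number here means a stronger inhibitor, a higher number a weaker inhibitor:
- Compound 1 `O=C(NCCNS(=O)(=O)c1ccc(-c2ccccc2OCc2cccc(O)c2)s1)Nc1cc(Cl)cc(Cl)c1`: > 50000 nM (a limit of the assay)
- Compound 2 `O=C(NCCNS(=O)(=O)c1ccc(-c2ccccc2Oc2ccc(O)c(O)c2)s1)Nc1cc(Cl)cc(Cl)c1`: 4500 nM
- Compound 3 `O=C(NCCNS(=O)(=O)c1ccc(-c2ccccc2Oc2ccc([N+](=O)[O-])c([N+](=O)[O-])c2)s1)Nc1cc(Cl)cc(Cl)c1`: 2100 nM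

Compound 3, at 2100 nM, has the lowest number in this small set. Compound 2 lies closest to it, and a 2.1-fold lower number from compound 2 to compound 3 (0.33 log units; beyond the scatter) is a modest step. Compound 1 gives no exact number, only a limit.

Compound 4 `O=C(NCCNS(=O)(=O)c1ccc(-c2ccccc2O[C@H]2CC[C@H](O)CC2)s1)Nc1cc(Cl)cc(Cl)c1` keeps the core of compound 3 and changes one group: 4-hydroxycyclohexyl in place of 3,4-dinitrophenyl on an oxygen on an aromatic ring. Here 4-hydroxycyclohexyl replaces 3,4-dinitrophenyl on an oxygen on an aromatic ring, so a non-aromatic ring enters where an aromatic one stood.

For the measured compounds named here, no measured compound carries a non-aromatic ring in this place, so the evidence is indirect. Exchanging one substituted phenyl group for another changed little, as a 2.1-fold lower number from compound 2 to compound 3 (0.33 log units; beyond the scatter) shows. Replacing the 3-hydroxybenzyl group changed far more, as an at least 11-fold lower number from compound 1 to compound 2 (1.04 log units; beyond the scatter) and an at least 23-fold lower number from compound 1 to compound 3 (1.37 log units; beyond the scatter) show, so this place can matter greatly. A moderate move to a higher number in this assay, meaning a weaker inhibitor, is therefore expected, with wide uncertainty. The estimated step is a 2.9-fold higher number from compound 3 to compound 4 (0.46 log units; beyond the scatter). For compound 4 the expected value is 6000 nM, with an estimated range of 1500 nM to 30000 nM.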

Compound 4, half-maximal inhibitory concentration: 14100 nM
For compound 4 the middle estimate is 2.4-fold (0.37 log units) below the measured one; measured number inside the range.
By their numbers in this assay, from the lowest: compound 3; then compound 2; then compound 4. At a limit, above all of these: compound 1.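

In this assay, putting a non-aromatic ring on this oxygen in place of a substituted phenyl group gives a 6.7-fold higher number from compound 3 to compound 4 (0.83 log units; beyond the scatter) and a 3.1-fold higher number from compound 2 to compound 4 (0.50 log units; beyond the scatter), so both phenyl groups shown, whether they carry nitro or hydroxyl groups, give lower numbers than 4-hydroxycyclohexyl. Compound 1 offers a limit rather than a number: the limit of > 50000 nM in this assay, at which 1 of the 4 values shown sits. Even so, 4-hydroxycyclohexyl still compares well with 3-hydroxybenzyl, with an at least 3.5-fold lower number from compound 1 to compound 4 (0.54 log units; beyond the scatter), which shows that an aromatic ring in this place is not needed for a value inside the measurable range.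

On these data alone, what a plain cyclohexyl group or a 4-aminocyclohexyl group would give on this oxygen remains open, so the share of the hydroxyl group in the value of compound 4 cannot be told from these compounds. Whether the two defined stereocentres matter is also open, as only one arrangement of the 4-hydroxycyclohexyl group appears among the compounds shown.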